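The compounds below may be only part of what the source reports. "The series", "measured", "known", "first", "only" and "open" are said of these compounds alone.

Measured so far in a functional assay on the whole organism (strain Swiss) with Mus musculus as the target, in the maximal electroshock model, with a stated time of 1 h, at a dose of 300 mg/kg by the intraperitoneal route; a lower number here means a weaker effect, a higher number a stronger effect of the compound at the dose given:

Compound 1, `CC(C(=O)N1CCN(c2ccc(Cl)cc2)CC1)N1C(=O)CCC1=O`: 0%
Compound 2, `CC(C(=O)N1CCN(c2ccccc2F)CC1)N1C(=O)CCC1=O`: 50%

Compound 2 stands highest of these two numbers; its nearest neighbour, compound 1, lies a long way below it. Among the compounds with values here, the only measured step is a number 50 percentage points higher from compound 1 to compound 2 (beyond the scatter), which is large and beyond the scatter, and it comes from 2-fluorophenyl in place of 4-chlorophenyl on an amine nitrogen in a ring.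

The unmeasured compound 3, `CC(C(=O)N1CCN(c2ccccc2Cl)CC1)N1C(=O)CCC1=O`, differs from compound 2 by chloro in place of fluoro on an aromatic carbon. Within the data shown here, the one measured step bears on this only loosely: it changed both the halogen and where it sits at once, so it cannot separate the share of the chloro-to-fluoro swap from the share of the new place. Among the measured compounds shown here, no measured pair shows chloro against fluoro at the same place.

Compound 3 is therefore expected to land near compound 2, with the step of a number 8 percentage points lower from compound 2 to compound 3 (within the scatter) expected to stay within the scatter, though with wide uncertainty. The estimate for compound 3 is 42%, with a range from 10% to 75%.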

Compound 3, a percentage reported as activity, at one dose (the size of the read-out at that dose, not a potency): 25%
For compound 3 the middle estimate is 17 percentage points above the measured one, and the stated range covers the measured number.
By their numbers in this assay, from the lowest: compound 1; then compound 3; then compound 2.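

In this assay, within the data shown here, chloro in place of fluoro at one unchanged place gives a number 25 percentage points lower from compound 2 to compound 3 (beyond the scatter) and so shows for the first time that the identity of the halogen on this ring matters by itself. With chloro kept and only its place changed, 2-chlorophenyl in place of 4-chlorophenyl gives a number 25 percentage points higher from compound 1 to compound 3 (beyond the scatter) and shows that the place of the halogen matters as well. The earlier step of a number 50 percentage points higher from compound 1 to compound 2 (beyond the scatter) changed both features at once, and these two new steps now divide it into two parts of the same printed size, although no measurement here explains why either change alters the effect.

Going by these compounds, it remains open whether 4-fluorophenyl would stand above or below the 4-chlorophenyl of compound 1, which would test whether the swap from chloro to fluoro has the same effect at that other place, and how a methoxy or a trifluoromethyl group on the aromatic carbon of compound 2 would compare with fluoro and chloro. Each read-out also describes a single dose and is not a potency, so the order of these compounds at other doses remains open too.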